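A few compounds are considered here, and "the series" means these few. Any claim that something is new, unique, unknown or untested is made for them only; others in the source may bear on it.

Measured so far in a functional assay on A549 cells (Homo sapiens) for antiproliferative activity, read by MTT assay, with a stated time of 72 h; a lower number here means a stronger inhibitor, a higher number a weaker inhibitor:
- compound 1 `O=C1COc2ccc(-c3cnc(Cl)c(NS(=O)(=O)c4ccc(F)cc4)c3)cc2N1c1ccc(Cl)cc1`: 21600 nM
- compound 2 `O=C1COc2ccc(-c3cnc(Cl)c(NS(=O)(=O)c4ccc(F)cc4)c3)cc2N1c1ccccc1`: 14700 nM
- compound 3 `O=C1COc2ccc(-c3cnc4ccccc4c3)cc2N1c1ccc(Cl)cc1`: > 40000 nM

Compound 2 differs from compound 1 by one change, (hydrogen in place of chloro on an aromatic carbon). That change gave a 1.5-fold lower number from compound 1 to compound 2 (0.17 log units; within the scatter), so the two values are not distinguished in this assay.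

Compound 3 has a different core, and the difference between the two cores is not broken down here. For compound 3 the result in this assay is a limit of the assay, not a number.

Compound 4 `O=C1COc2ccc(-c3cnc4ccccc4c3)cc2N1c1ccccc1` has not yet been measured. It differs from compound 3 by hydrogen in place of chloro on an aromatic carbon, the same change as from compound 1 to compound 2, at the same kind of place. The step is expected to be about as small as the earlier one, a step that the limit leaves unreadable from compound 3 to compound 4, an expectation resting on a 1.5-fold lower number from compound 1 to compound 2 (0.17 log units; within the scatter). Since compound 3 already sits at the limit of > 40000 nM in this assay, at which 1 of the 3 values shown sits, compound 4 may also return only a limit. Compound 4 is expected to give about 50000 nM, between 25000 nM and 150000 nM.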

Compound 4, half-maximal inhibitory concentration: > 40000 nM
Compound 4: only a limit was reported; the forecaster's own chance of this, stated with the estimate: 60%; the middle value does not contradict the limit.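

In this assay compound 4 gives > 40000 nM, which is a limit of the assay and not a number. Compound 3 also gives only a limit, so no step from compound 3 to compound 4 can be read: the limit of > 40000 nM in this assay, at which 2 of the 4 values shown sit.

The compounds shown leave open whether going from 4-chlorophenyl to phenyl changes activity at all on the core of compound 3.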